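Bromo for Chloro on the Thiourea Aryl Ring

The source may hold more compounds than are shown below. What is called first, only, known or untested is meant among the compounds shown, and "the series" means these compounds.

Compound 1 `C=CCNC(=S)NC1=C(C#N)C(c2ccc(Cl)cc2Cl)C2=C(CCCC2=O)N1c1ccc(S(N)(=O)=O)cc1` in a functional assay on Ehrlich cells (Mus musculus) for cytotoxicity, read by trypan blue exclusion, with a stated time of 2 h, tested at 100 ug/mL; a higher number here means a stronger effect of the compound at the concentration tested, a lower number a weaker effect: 40%
Compound 2 `N#CC1=C(NC(=S)Nc2ccc(Cl)cc2)N(c2ccc(S(N)(=O)=O)cc2)C2=C(C(=O)CCC2)C1c1ccc(Cl)cc1Cl` in this assay: 100%

Going by the values given here, compound 2 stands highest of the two numbers measured so far, and the one step between them, a number 60 percentage points higher from compound 1 to compound 2 (beyond the scatter), is large and beyond the scatter. That step came with 4-chlorophenyl in place of allyl on an amide-type nitrogen, a change of an entire substituent rather than of one atom within it.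

Compound 3 `N#CC1=C(NC(=S)Nc2ccc(Br)cc2)N(c2ccc(S(N)(=O)=O)cc2)C2=C(C(=O)CCC2)C1c1ccc(Cl)cc1Cl` differs from compound 2 by bromo in place of chloro on an aromatic carbon. Among the compounds with values here, no measured step concerns an exchange of one halogen for another on that ring, so the single known step, large as it is, does not bear on this change. With nothing to suggest movement, the estimated step is a number 5 percentage points lower from compound 2 to compound 3 (within the scatter), which is expected to lie within the scatter. Compound 3 is therefore estimated at 95%, with a range from 75% to 100%.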

Compound 3, a percentage reported as activity, at one concentration (the size of the read-out at that concentration, not a potency): 90%
Estimate against measurement, compound 3: 5 percentage points above, within the range that was stated.
By their numbers in this assay, from the lowest: compound 1; then compounds 3 and 2 (each within the scatter of the next).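

In this assay, bromo in place of chloro on this aromatic carbon gives a number 10 percentage points lower from compound 2 to compound 3 (within the scatter) and so does not separate the two compounds, which the earlier pair, differing by an entire substituent, could not show. The large gain over allyl on the amide-type nitrogen is also not tied to chloro, since 4-bromophenyl in place of allyl gives a number 50 percentage points higher from compound 1 to compound 3 (beyond the scatter) as well. Nothing at hand speaks to the reason for this result.

The compounds shown leave open whether this read-out depends on a halogen at all, as a plain phenyl ring, or a fluoro, methoxy or amino group on the same carbon, would test. They also leave open whether a group on another carbon of that ring would do the same.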